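Replacing the Pyrimidinyl Thioether Group with a Butyl Chain

The compounds below may be only part of what the source reports. "The series", "measured", "known", "first", "only" and "open" are said of these compounds alone.

Compound 1 `O=C(CSc1ncccn1)N1N=C(c2cc3ccccc3oc2=O)C[C@@H]1c1ccc(C(F)(F)F)cc1` is the stronger of the two compounds measured in a functional assay on MGC-803 cells (Homo sapiens) for cytotoxicity, read by MTT assay, with a stated time of 48 h (a lower number here means a stronger inhibitor, a higher number a weaker inhibitor), where compound 1 gives 2890 nM. Compound 2 `O=C(CSc1ccc(Br)cc1)N1N=C(c2cc3ccccc3oc2=O)C[C@@H]1c1ccc(C(F)(F)F)cc1` differs from it only by carrying 4-bromophenyl in place of pyrimidin-2-yl on a sulfur, and in this assay compound 2 gives 10800 nM; the step of a 3.7-fold higher number from compound 1 to compound 2 (0.57 log units; beyond the scatter) shows that exchanging the pyrimidin-2-yl for a six-membered carbon ring weakened the inhibition by a modest but real amount. Compound 3 `CCCCSCC(=O)N1N=C(c2cc3ccccc3oc2=O)C[C@@H]1c1ccc(C(F)(F)F)cc1` is the next variation of the same shared core: butyl in place of pyrimidin-2-yl on a sulfur. Going by the values given here, only the step from compound 1 to compound 2 bears on this change, and it points to weaker inhibition when the pyrimidin-2-yl is lost, so a modest rise in the number is expected, with wide uncertainty because a chain is not a ring. For compound 3 the estimated value in this assay is 5500 nM, between 1500 nM and 20000 nM, an expected step of a 1.9-fold higher number from compound 1 to compound 3 (0.28 log units; within the scatter).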

Compound 3, half-maximal inhibitory concentration: 2350 nM
Compound 3: the middle estimate sits 2.3-fold (0.37 log units) above what was measured, and the stated range covers the measured number.
By their numbers in this assay, from the lowest: compounds 3 and 1 (each within the scatter of the next); then compound 2.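

In this assay, a 1.2-fold lower number from compound 1 to compound 3 (0.09 log units; within the scatter) puts compound 3 level with compound 1, so at this sulfur a butyl chain with no ring serves as well as the pyrimidin-2-yl ring. The other new step, a 4.6-fold lower number from compound 2 to compound 3 (0.66 log units; beyond the scatter), shows that the weaker result for compound 2 cannot be read as a general cost of losing the pyrimidin-2-yl, since compound 3 lacks that ring too. Among these three compounds, only compound 2, with its 4-bromophenyl, stands apart.

Still open, from the compounds shown here alone, is whether a shorter chain such as ethyl, a longer chain such as octyl, or a butyl chain ending in an amine or a carboxylic acid would hold this level. Also open, going by these compounds, is whether a plain phenyl would behave like the 4-bromophenyl. Nothing available here explains why these groups compare as they do.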